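This account rests on a few compounds, and the source may have more. Where it says the series, first, only, none or still open, it means among the compounds named here.

Compound 1 `CCCCCCCCCCCCCCCCCC(=O)OCCCOP(=O)(O)OC[C@H](N)C(=O)O`: 40 nM
Compound 2 `CCCCCCCCCCCCCCCCCC(=O)OC[C@@H](COP(=O)(O)OC[C@H](N)C(=O)O)OC`: "not determined" (no result reported)

Going by the values given here, in a functional assay on cells (Mast cell, Mus musculus, strain C57BL/6) for activation, read by fluorescence, with a stated time of 15 min (a lower number here means that less compound is needed, a higher number that more compound is needed for the effect), compound 1 gives 40 nM, the only number so far. On these data alone, for compound 2 the entry reads "not determined" (no result reported), so it offers no comparison, and where compound 1 stands among related compounds remains open.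

Compound 3 `CCCCCCCCCCCCCCCCCC(=O)OCCCOP(=O)(O)O[C@H](C)[C@H](N)C(=O)O` differs from compound 1 in one place: methyl in place of hydrogen on a saturated chain carbon bound to an oxygen and a saturated chain carbon. This is methyl in place of hydrogen on a saturated chain carbon bound to an oxygen and a saturated chain carbon. Among the compounds with values here, no measured pair of compounds shows what such a change does, so what follows is a judgement rather than a trend. In this assay a modest move toward a lower number is expected, with the estimated step of a 2.7-fold lower number from compound 1 to compound 3 (0.43 log units; beyond the scatter). For compound 3 the expected value is 15 nM, with an estimated range of 4 nM to 50 nM.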

Compound 3, half-maximal effective concentration: 7 nM
Estimate against measurement, compound 3: 2.1-fold (0.33 log units) above; measured number inside the range.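

In this assay the swap of hydrogen for methyl on a saturated chain carbon bound to an oxygen and a saturated chain carbon gives a 5.7-fold lower number from compound 1 to compound 3 (0.76 log units; beyond the scatter), which is beyond the usual scatter. This shows that the position can carry one added carbon and that, here, the effect then needs less compound rather than more. What lies behind the change in the number cannot be said from the information available.

One methyl at one position says nothing yet about how far the trend runs: an ethyl group, a longer chain or a hydroxymethyl group at this carbon could carry it further or reverse it. On these data alone, whether the methyl has the same effect on other cores stays open too, and compound 2 has no number to help.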